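Trifluoromethoxy for Cyclopentyl on the Shared Core

The source may report more compounds than this note shows. Statements on the series, on what has been measured and on what is new or still open speak of the compounds shown alone.

Values in an assay on isolated protein for inhibition of tyrosine-protein kinase receptor UFO (Homo sapiens), read by FRET and Z'-LYTE, with a stated time of 1.5 h; a lower number here means a stronger inhibitor, a higher number a weaker inhibitor:
compound 1 `Cc1c(C(=O)Nc2ccc(Oc3ncnc4[nH]cc(-c5ccccc5)c34)c(F)c2)c(=O)c2cc(F)ccc2n1C`: a limit of the assay, > 10000 nM
compound 2 `Cc1c(C(=O)Nc2ccc(Oc3ncnc4[nH]cc(-c5ccccc5)c34)c(F)c2)c(=O)c2cc(C(F)(F)F)ccc2n1C`: 150 nM
compound 3 `Cc1c(C(=O)Nc2ccc(Oc3ncnc4[nH]cc(-c5ccccc5)c34)c(F)c2)c(=O)c2cc(C3CCCC3)ccc2n1C`: 200 nM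

Compound 3 gives the highest of the two numbers shown, but the distinction is only a 1.3-fold higher number from compound 2 to compound 3 (0.12 log units; within the scatter) and lies within the scatter. Compound 1 sits at the limit of > 10000 nM in this assay, at which 1 of the 3 values shown sits. Compound 4 `Cc1c(C(=O)Nc2ccc(Oc3ncnc4[nH]cc(-c5ccccc5)c34)c(F)c2)c(=O)c2cc(OC(F)(F)F)ccc2n1C` is not yet measured; it differs from compound 3 by trifluoromethoxy in place of cyclopentyl on an aromatic carbon. Among the measured compounds shown here, two measured steps touch this position: an at least 50-fold lower number from compound 1 to compound 3 (1.69 log units; beyond the scatter) and an at least 66-fold lower number from compound 1 to compound 2 (1.82 log units; beyond the scatter), both large, whereas a 1.3-fold higher number from compound 2 to compound 3 (0.12 log units; within the scatter) is within the scatter. Both groups measured beyond fluoro at this position thus gave closely similar numbers, while fluoro gave only a limit. Trifluoromethoxy itself has not been measured here. Because the two groups already measured differ by a 1.3-fold higher number from compound 2 to compound 3 (0.12 log units; within the scatter), compound 4 is expected to show a 1.3-fold higher number from compound 3 to compound 4 (0.10 log units; within the scatter), no step beyond the scatter. Compound 4 is therefore estimated at 250 nM, with a range from 80 nM to 800 nM.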

Compound 4, half-maximal inhibitory concentration: 74 nM
Compound 4: the middle estimate sits 3.4-fold (0.53 log units) above what was measured; measured number outside the range, below it.
By their numbers in this assay, from the lowest: compound 4; then compounds 2 and 3 (each within the scatter of the next). At a limit, above all of these: compound 1.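

In this assay the position proves not to be flat beyond fluoro: trifluoromethoxy separates from both earlier groups, with a 2.7-fold lower number from compound 3 to compound 4 (0.43 log units; beyond the scatter) and a 2.0-fold lower number from compound 2 to compound 4 (0.31 log units; beyond the scatter), whereas cyclopentyl and trifluoromethyl could not be told apart. Exchanging a ring of carbon only for an open group of the same heavy-atom count that carries a hydrogen-bond acceptor thus moves the number modestly, though these compounds cannot say which of those differences matters. The change from fluoro shows an at least 130-fold lower number from compound 1 to compound 4 (2.13 log units; beyond the scatter), and the size of that step rests on a limit of the assay: the limit of > 10000 nM in this assay, at which 1 of the 4 values shown sits.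

The compounds shown leave open whether the oxygen link itself counts, which methoxy or a longer chain such as ethoxy at this place would test. They also leave open how an amine or a carboxylic acid would fare there.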